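Compound 1 and a new side arm: what to expect

The source may report more compounds than this note shows. Statements on the series, on what has been measured and on what is new or still open speak of the compounds shown alone.

Three compounds have been measured in a functional assay (aorta) with Rattus norvegicus as the target; on this read-out higher numbers stand for an effect only at larger amounts of compound and lower numbers for an effect already at smaller amounts:

Compound 1 `COc1ccc(-c2nc(/N=C(\N)N(C)C)sc2-c2ccc(OC)cc2)cc1`: 4.8 uM
Compound 2 `COc1ccc(-c2nc(CNC(=O)c3cccnc3)sc2-c2ccc(OC)cc2)cc1`: 8.2 uM
Compound 3 `COc1ccc(-c2nc(CNC(=O)CSC)sc2-c2ccc(OC)cc2)cc1`: 6 uM

Compound 1 stands at the lowest of these three numbers, but its distances to compound 3 and to compound 2 both lie within the usual scatter, so the three compounds cannot be ranked against one another on this read-out.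

Compound 4 `CCOC(=O)/C=C/c1nc(-c2ccc(OC)cc2)c(-c2ccc(OC)cc2)s1` has not yet been measured. Compared with compound 1 the change is a group of 7 heavy atoms (5 carbon, 2 oxygen; no ring) in place of a group of 6 heavy atoms (3 carbon, 3 nitrogen; no ring), on an aromatic carbon. The group that leaves is the same one that left in the two measured steps, and in both it was replaced by another group at the same aromatic carbon. Those steps were a 1.7-fold higher number from compound 1 to compound 2 (0.23 log units; within the scatter) and a 1.3-fold higher number from compound 1 to compound 3 (0.10 log units; within the scatter), each inside the scatter. Two different replacements of this group left the number essentially unchanged, so a small step is expected here as well, most likely none beyond the scatter and, if anything, toward a slightly higher number: a 1.5-fold higher number from compound 1 to compound 4 (0.16 log units; within the scatter) is the expected step. For compound 4 the estimated value in this assay is 7 uM, expected to fall between 2.5 uM and 20 uM.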

Compound 4, concentration for half-maximal effect: > 100 uM
Compound 4: a limit, no number (the forecaster's own chance of this, stated with the estimate: 5%); middle value at least 14-fold (1.15 log units) away from the limit.
By their numbers in this assay, from the lowest: compounds 1, 3 and 2 (each within the scatter of the next). At a limit, above all of these: compound 4.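

In this assay the result for compound 4 is a limit and not a number: the limit of > 100 uM in this assay, at which 1 of the 4 values shown sits.

Earlier, this aromatic carbon seemed to accept quite different groups, but the new steps are all large and beyond the scatter (an at least 20-fold higher number from compound 1 to compound 4 (1.31 log units; beyond the scatter); an at least 16-fold higher number from compound 3 to compound 4 (1.22 log units; beyond the scatter); an at least 12-fold higher number from compound 2 to compound 4 (1.08 log units; beyond the scatter)), so the position is clearly sensitive to what it carries. The comparison also separates the groups: the group of compound 1 has a hydrogen-bond donor and compounds 2 and 3 each have an amide hydrogen, while 2-(ethoxycarbonyl)ethenyl has no hydrogen-bond donor and is the only one of the four that goes with the large step.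

With only these four compounds, that link remains an observation, and the double bond, the ethyl ester and the missing donor all change together, so none of them can be singled out as responsible. A carboxylic acid in place of the ethyl ester, a saturated two-carbon chain in place of the double bond, or an amide carrying its own hydrogen on the same chain would each change just one of these features.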